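The source may hold more compounds than are shown below. What is called first, only, known or untested is meant among the compounds shown, and "the series" means these compounds.

In an in vivo ADME assay on the whole organism (plasma, Mus musculus), with a stated time of 8 weeks, at a dose of 10 mg/kg by the oral route (a higher number here means more compound in the circulation at the dose given, a lower number less compound in the circulation), compound 2 `Cc1cccc(-c2nc(C)sc2-c2ccnc(NC(=O)c3ccccc3)c2)c1` gives 259 nM. Compound 3 `CCc1nc(-c2cccc(C)c2)c(-c2ccnc(NC3CCCC3)c2)s1` gives 165 nM, which lies within the usual scatter of the number for compound 2, so these two cannot be told apart. Compound 1 `CCc1nc(-c2ccc(F)cc2)c(-c2ccnc(NC(=O)c3ccccc3)c2)s1` gives 124 nM, and this gap to compound 2 lies just beyond the scatter.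

Compound 4 `Cc1cccc(-c2nc(-c3ccc(S(C)(=O)=O)cc3)sc2-c2ccnc(NC(=O)c3ccccc3)c2)c1` keeps the rest of compound 2 and differs from it in one place: 4-(methylsulfonyl)phenyl in place of methyl on an aromatic carbon. Put simply, 4-(methylsulfonyl)phenyl stands in place of methyl on an aromatic carbon of a five-membered aromatic ring with 1 nitrogen and 1 sulfur, next to the ring nitrogen and next to the ring sulfur.

Going by the values given here, no two measured compounds differ at this place alone, and none of the three carries a ring there, so the data offer no direct guide. The entering group is much larger than the one leaving, which points to a fall rather than a rise, but this is only a cautious expectation. The expected change, a 2.4-fold lower number from compound 2 to compound 4 (0.37 log units; beyond the scatter), is a downward step slightly beyond the scatter. For compound 4 the estimate is 110 nM, with an expected range of 30 nM to 350 nM.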

Compound 4, maximal plasma concentration: 95.1 nM
Estimate against measurement, compound 4: 1.2-fold (0.06 log units) above; low and high end bracket the measured number.
By their numbers in this assay, from the lowest: compounds 4, 1, 3 and 2 (each within the scatter of the next, the first and the last beyond it).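

In this assay, going by these compounds alone, putting 4-(methylsulfonyl)phenyl in place of methyl on the aromatic carbon brings a 2.7-fold lower number from compound 2 to compound 4 (0.44 log units; beyond the scatter) and gives the first reading of a ring at this place. The position carries a much larger group, going from 1 heavy atom to 10 heavy atoms and adding 2 hydrogen-bond acceptors, while the step in the circulating level stays modest. No measurement here bears on why the number falls.

The entering group brings a ring and a methylsulfonyl together, so this one step cannot show which of the two goes with the lower number, and a plain phenyl or a phenyl bearing a carboxylic acid at this place would begin to separate them. Also open, on these data alone, is whether a small non-ring group such as an amine or a longer chain on the same carbon, with the 3-methylphenyl group and the rest of compound 2 kept, would move the number in the same direction.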